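Cytotoxicity notes: compound 3 to compound 4

The source may hold more compounds than are shown below. What is called first, only, known or untested is meant among the compounds shown, and "the series" means these compounds.

For the measured compounds named here, compound 3 `OC[C@H]1O[C@@H](n2cnc3c(CN4CCCCC4)ncnc32)[C@H](O)[C@@H]1O` stands as the only plain number in a functional assay on Huh-7 cells (Homo sapiens) for cytotoxicity, read by MTT assay, with a stated time of 3 days; a higher number here means that more compound is tolerated, a lower number that less compound is tolerated: compound 3 gives 87000 nM. Compound 1 `OC[C@H]1O[C@@H](n2cnc3c(COc4ccccn4)ncnc32)[C@H](O)[C@@H]1O` sits at a limit of this assay, > 250000 nM. Compound 2 `O=C(O)CNCc1ncnc2c1ncn2[C@@H]1O[C@H](CO)[C@@H](O)[C@H]1O` likewise sits at a limit, > 100000 nM. The steps onto compound 3 read an at least 2.8-fold lower number from compound 1 to compound 3 (0.45 log units; beyond the scatter) and an at least 1.1-fold lower number from compound 2 to compound 3 (0.06 log units; that floor lies within the scatter), so compound 3 is the most cytotoxic member of the trio seen so far. Compound 4 `O=c1ccccn1Cc1ncnc2c1ncn2[C@@H]1O[C@H](CO)[C@@H](O)[C@H]1O` differs from compound 3 by a group of 7 heavy atoms (5 carbon, 1 nitrogen, 1 oxygen; one six-membered aromatic ring with 1 hetero atom) in place of a group of 6 heavy atoms (5 carbon, 1 nitrogen; one six-membered non-aromatic ring with 1 hetero atom), on a saturated chain carbon bound to an aromatic carbon. The entering group is close kin to the (pyridin-2-yl)oxy of compound 1, whose value was a limit (the limit of > 250000 nM in this assay, at which 1 of the 3 values shown sits), so a higher number, and quite possibly another limit, is expected. Compound 4 is estimated at 200000 nM, range 70000 nM to 500000 nM, an expected step of a 2.3-fold higher number from compound 3 to compound 4 (0.36 log units; beyond the scatter).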

Compound 4, half-maximal cytotoxic concentration: > 100000 nM
Compound 4: only a limit was reported; the forecaster's own chance of this, stated with the estimate: 55%; the middle value lies beyond the limit too.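

With the aromatic ring group in place of piperidin-1-yl on the saturated chain carbon, this assay gives an at least 1.1-fold higher number from compound 3 to compound 4 (0.06 log units; that floor lies within the scatter), so this floor alone does not separate the two compounds. Compound 4 is reported only as a limit of the assay: the limit of > 100000 nM in this assay, at which 2 of the 4 values shown sit.
For the compounds shown here, the steps from compound 1 and compound 2 to compound 4 cannot be read, since both ends are limits, and compound 3 remains the only plain number.

As far as these compounds go, how far compound 4 actually lies from compound 3 stays open. Also open, from the compounds shown here alone, is whether another amine on this carbon, such as morpholin-4-yl or dimethylamino, would give a plain number.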